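Removing the pentyl from the selenium of compound 2

This account rests on a few compounds, and the source may have more. Where it says the series, first, only, none or still open, it means among the compounds named here.

Measured compounds:
compound 1, `Sc1nc(NCc2ccccc2)c2ccccc2n1`: > 100000 nM
compound 2, `CCCCC[Se]c1nc(NCc2ccccc2)c2ccccc2n1`: 72500 nM

Compound 1, `Sc1nc(NCc2ccccc2)c2ccccc2n1`, carries a sulfur on an aromatic carbon of the shared core. In a functional assay on CCRF-CEM cells (Homo sapiens) for cytotoxicity, read by MTT assay, with a stated time of 72 h (a higher number here means a weaker inhibitor of growth, a lower number a stronger inhibitor of growth), compound 1 gives > 100000 nM, which is a limit of the assay and not a number. Going by the values given here, compound 2, `CCCCC[Se]c1nc(NCc2ccccc2)c2ccccc2n1`, gives 72500 nM in this assay, the only actual number among the two values. Among the compounds with values here, the step of an at least 1.3-fold lower number from compound 1 to compound 2 (0.13 log units; that floor lies within the scatter) is the sole measured step, and its floor sits at the limit of > 100000 nM in this assay, at which 1 of the 2 values shown sits.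

Compound 3, `[SeH]c1nc(NCc2ccccc2)c2ccccc2n1`, is not yet measured. It differs from compound 2 by hydrogen in place of pentyl on a selenium. Within the data shown here, the only measured step that bears on this is an at least 1.3-fold lower number from compound 1 to compound 2 (0.13 log units; that floor lies within the scatter), in which the pentylselenyl group entered in place of sulfur and the number fell, at least at its floor; the change from compound 2 to compound 3 undoes the pentyl while keeping the selenium, so the number is expected to rise again, possibly back toward the limit. Compound 3 is therefore estimated at 100000 nM, within 50000 nM to 300000 nM, an expected step of a 1.4-fold higher number from compound 2 to compound 3 (0.14 log units; within the scatter).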

Compound 3, concentration for total growth inhibition: > 100000 nM
Compound 3: only a limit was reported; the forecaster's own chance of this, stated with the estimate: 55%; the middle value lies on the limit itself.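

In this assay the removal of the pentyl from the selenium gives an at least 1.3-fold higher number from compound 2 to compound 3 (0.13 log units; that floor lies within the scatter) and so offers only a floor, one that does not by itself show the pentyl to matter. Compound 3 gives > 100000 nM and this is a limit of the assay and not a number. What the result adds is that selenium carrying only hydrogen gives no readable number at this position, just as sulfur did in compound 1, and the step between those two compounds cannot be read, since both stand at the limit: the limit of > 100000 nM in this assay, at which 2 of the 3 values shown sit.

Going by these compounds, how far beyond that limit compound 1 and compound 3 lie remains unknown, so it stays open whether the pentyl on selenium contributes anything beyond the scatter. Also open, on these data alone, is how a methyl, a benzyl or a longer chain such as decyl on the selenium would read in this assay and whether a pentyl on sulfur would match compound 2.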